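A few compounds are considered here, and "the series" means these few. Any claim that something is new, unique, unknown or untested is made for them only; others in the source may bear on it.

Within the data shown here, in a functional assay on KYSE-450 cells (Homo sapiens) for inhibition, read by CCK-8 assay, with a stated time of 48 h (a lower number here means a stronger inhibitor, a higher number a weaker inhibitor), compound 1 `COc1ccc(CN(C(=O)CSC(=S)N2CCN(C)CC2)c2cc(OC)c(OC)c(OC)c2)cc1` gives 1250 nM, the lowest number among the compounds measured so far. Compound 2 `COc1ccc(CN(C(=O)CSC(=S)N2CCCc3cc(OC)ccc32)c2cc(OC)c(OC)c(OC)c2)cc1` gives 5530 nM. Compound 3 `COc1ccc(CN(C(=O)CSC(=S)N2CCc3ccccc3C2)c2cc(OC)c(OC)c(OC)c2)cc1` gives > 20000 nM, which is a limit of the assay. Compound 4 `COc1ccc(CN(C(=O)CN2CCN(C(C)=O)CC2)c2cc(OC)c(OC)c(OC)c2)cc1` is not yet measured, and its difference from compound 1 is a group of 9 heavy atoms (6 carbon, 2 nitrogen, 1 oxygen; one six-membered non-aromatic ring with 2 hetero atoms) in place of a group of 10 heavy atoms (6 carbon, 2 nitrogen, 2 sulfur; one six-membered non-aromatic ring with 2 hetero atoms), on a saturated chain carbon bound to a carbonyl carbon, with 4-acetylpiperazin-1-yl now on a saturated chain carbon bound to a carbonyl carbon. The closest evidence comes from ring swaps on the thiocarbonyl carbon, a 4.4-fold higher number from compound 1 to compound 2 (0.65 log units; beyond the scatter) and an at least 16-fold higher number from compound 1 to compound 3 (1.20 log units; beyond the scatter), though neither swap removes that carbon. Both point upward, so a modest rise is expected, and the estimated change is a 3.2-fold higher number from compound 1 to compound 4 (0.51 log units; beyond the scatter). For compound 4, the expected value is 4000 nM, within a range of 1200 nM to 15000 nM.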

Compound 4, half-maximal inhibitory concentration: 10800 nM
Compound 4: middle estimate off by 2.7-fold (0.43 log units), on the low side, and the stated range covers the measured number.
By their numbers in this assay, from the lowest: compound 1; then compounds 2 and 4 (each within the scatter of the next). At a limit, above all of these: compound 3.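

In this assay the swap to 4-acetylpiperazin-1-yl, which removes both sulfur atoms, gives an 8.6-fold higher number from compound 1 to compound 4 (0.94 log units; beyond the scatter) and so extends the evidence from ring swaps on the thiocarbonyl carbon to the whole group on this saturated chain carbon. Compound 4 keeps a six-membered non-aromatic ring with 2 hetero atoms, so that ring alone does not preserve the number of compound 1. Nothing measured here gives a cause for this rise. The sulfur-containing link and the ring substituent changed together, so their shares cannot be separated. A 4-methylpiperazin-1-yl or morpholin-4-yl group placed directly on this chain carbon would help to separate them.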